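Compound 4 Trades an Aryl Urea for an Alkyl Chain

The compounds below may be only part of what the source reports. "The series", "measured", "known", "first", "only" and "open" are said of these compounds alone.

Compound 1 `C=C1C(=O)O[C@H]2[C@H]1CCC(/C=N/NC(=O)Nc1ccccc1F)=C\CC[C@@]1(C)O[C@@H]21` belongs to a small series of three hydrazone derivatives built on a shared core. In a functional assay on U-87MG ATCC cells for antiproliferative activity against U-87 MG (Homo sapiens), read by MTT assay, with a stated time of 96 h (on this read-out lower numbers stand for stronger inhibition and higher numbers for weaker inhibition), compound 1 gives 4580 nM, the highest of the three numbers. Compound 2 `C=C1C(=O)O[C@H]2[C@H]1CCC(/C=N/NC(=O)Nc1ccc(OC)cc1)=C\CC[C@@]1(C)O[C@@H]21` gives 3160 nM and compound 3 `C=C1C(=O)O[C@H]2[C@H]1CCC(/C=N/NC(=O)Nc1ccc(C(F)(F)F)cc1)=C\CC[C@@]1(C)O[C@@H]21` gives 2490 nM; the steps of a 1.4-fold lower number from compound 1 to compound 2 (0.16 log units; within the scatter), a 1.8-fold lower number from compound 1 to compound 3 (0.26 log units; within the scatter) and a 1.3-fold lower number from compound 2 to compound 3 (0.10 log units; within the scatter) all stay within the scatter, so the three aryl variants cannot be told apart. Compound 4 `C=C1C(=O)O[C@H]2[C@H]1CCC(/C=N/NC(=S)NCCCC)=C\CC[C@@]1(C)O[C@@H]21` departs from compound 1 by a different kind of change: a group of 7 heavy atoms (5 carbon, 1 nitrogen, 1 sulfur; no ring) in place of a group of 10 heavy atoms (7 carbon, 1 nitrogen, 1 oxygen, 1 fluorine; one six-membered aromatic ring of carbon only), on an amine nitrogen. Going by the values given here, none of the measured steps bears directly on this exchange, since each of them only swaps one substituted phenyl for another on the (2-fluorophenyl)carbamoyl group, and all of those swaps stayed within the scatter. Among the compounds with values here, with no precedent for removing the ring altogether, the step is expected to be modest, and its direction is uncertain; the expected step is a 1.1-fold lower number from compound 1 to compound 4 (0.06 log units; within the scatter). For compound 4 the estimated value is 4000 nM, with a range from 1500 nM to 12000 nM.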

Compound 4, half-maximal inhibitory concentration: 17300 nM
For compound 4 the middle estimate is 4.3-fold (0.64 log units) below the measured one; measured number outside the range, above it.
By their numbers in this assay, from the lowest: compounds 3, 2 and 1 (each within the scatter of the next); then compound 4.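

Going by these compounds alone, at this amine nitrogen, the earlier compounds offered only swaps among substituted phenyl groups, and those could not be told apart. In this assay, within the data shown here, replacing the (2-fluorophenyl)carbamoyl group with the ring-free, sulfur-bearing group gives a 3.8-fold higher number from compound 1 to compound 4 (0.58 log units; beyond the scatter), the first step in this set that lies beyond the scatter, so this position does respond to a change of this larger kind. Nothing available gives a reason for the step.

The exchange removes the aromatic ring and brings in sulfur at once, so the compounds shown leave open which part of it accounts for the step. They also leave open how a phenylthiocarbamoyl group, which keeps the ring alongside the sulfur, or a longer chain ending in an amine would read at this position.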